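Methyl in place of hydrogen at an aromatic nitrogen

The compounds below may be only part of what the source reports. "The series", "measured", "known", "first", "only" and "open" are said of these compounds alone.

Compound 1, `Cn1c(-c2ccccc2)nnc1S(C)(=O)=O`, gives in a functional assay on the whole organism for antagonist activity, with Mus musculus as the target, in the maximal electroshock model (a higher number here means that more compound is needed for the effect, a lower number that less compound is needed), a limit of > 200 mg/kg.
Compound 2, `CCS(=O)(=O)c1nnc(-c2ccccc2)n1C`, gives in this assay a limit of > 200 mg/kg.
Compound 3, `CSc1nnc(-c2ccc(Cl)cc2)n1C`, gives in this assay a limit of > 200 mg/kg.

From compound 1 to compound 2 the change is methyl in place of hydrogen on a saturated chain carbon bound to a sulfonyl sulfur. Both values are limits, and the step that the two limits leave unreadable from compound 1 to compound 2 cannot be read; every measured value sits at the limit of > 200 mg/kg in this assay, at which 3 of the 3 values shown sit. Compound 4, `CCn1c(SC)nnc1-c1ccc(Cl)cc1`, differs from compound 3 by methyl in place of hydrogen on a saturated chain carbon bound to an aromatic nitrogen, the same kind of change, though here the place is a saturated chain carbon bound to an aromatic nitrogen rather than to a sulfonyl sulfur. The difference between the cores of compound 1 and compound 3 is not broken down here. The measured pair offers no step size to carry over. Compound 4 is expected to give about 300 mg/kg, between 150 mg/kg and 800 mg/kg, an expected step that the limit leaves unreadable from compound 3 to compound 4 that is essentially flat, because compound 3 rests at the limit of > 200 mg/kg in this assay, at which 3 of the 3 values shown sit.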

Compound 4, dose for half-maximal effect: > 50 mg/kg
Compound 4 ended at the assay's limit (the forecaster's own chance of this, stated with the estimate: 85%); the middle value does not contradict the limit.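

For the compounds shown here, compound 3 and compound 4 are both known only as limits, and no step between them can be read. The compounds shown leave open whether this methyl changes the dose needed in this assay at all.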